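The compounds below may be only part of what the source reports. "The series", "measured", "known", "first", "only" and "open" are said of these compounds alone.

Measured so far in a functional assay on A549 cells (Homo sapiens) for cytotoxicity, read by MTT assay, with a stated time of 72 h; a lower number here means a stronger inhibitor, a higher number a weaker inhibitor:
compound 1 `CNC(=O)c1cc(Oc2ccc(C3=NNC(c4ccc(Cl)cc4Cl)C3)cc2)ccn1`: 6930 nM
compound 2 `CNC(=O)c1cc(Oc2ccc(C3=NNC(c4cccc(Br)c4)C3)cc2)ccn1`: 2840 nM
compound 3 `CNC(=O)c1cc(Oc2ccc(C3=NNC(c4ccccc4)C3)cc2)ccn1`: 8600 nM

Compound 3 is not separated from compound 1, with a 1.2-fold higher number from compound 1 to compound 3 (0.09 log units; within the scatter). It does lie on the weaker side of compound 2, with a 3.0-fold higher number from compound 2 to compound 3 (0.48 log units; beyond the scatter).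

The next compound is compound 4 `CNC(=O)c1cc(Oc2ccc(C3=NNC(c4cccc(Cl)c4Cl)C3)cc2)ccn1`, not yet measured. It has 2,3-dichlorophenyl in place of phenyl on a saturated ring carbon.

Two measured comparisons bear on this change. The closest is with compound 1, which carries 2,4-dichlorophenyl and shows no separation from the phenyl of compound 3 (a 1.2-fold higher number from compound 1 to compound 3 (0.09 log units; within the scatter)). This suggests that a dichlorophenyl group need not move the number at all. Compound 2 goes against that reading: its 3-bromophenyl group stands apart from the phenyl of compound 3, with a 3.0-fold higher number from compound 2 to compound 3 (0.48 log units; beyond the scatter). That step is modest, and it sets a reasonable upper size for any change here.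

With only these three compounds, a small move towards a lower number is expected, and it may well stay within the scatter. The expected step is a 1.7-fold lower number from compound 3 to compound 4 (0.24 log units; within the scatter). The estimated value for compound 4 is 5000 nM, with an expected range of 2200 nM to 10000 nM.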

Compound 4, half-maximal inhibitory concentration: 12100 nM
Compound 4: middle estimate off by 2.4-fold (0.38 log units), on the low side, and the stated range ends below it.
By their numbers in this assay, from the lowest: compound 2; then compounds 1, 3 and 4 (each within the scatter of the next).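

In this assay, the 2,3-dichlorophenyl group on this saturated ring carbon, next to the ring nitrogen, is not separated from phenyl (a 1.4-fold higher number from compound 3 to compound 4 (0.15 log units; within the scatter)) or from 2,4-dichlorophenyl (a 1.7-fold higher number from compound 1 to compound 4 (0.24 log units; within the scatter)), so compounds 1, 3 and 4 form a single group on this read-out. Compound 2 now stands apart from all three, and its gap to the new compound is the largest step in the set (a 4.3-fold higher number from compound 2 to compound 4 (0.63 log units; beyond the scatter)), which means that the lower number seen with 3-bromophenyl does not extend to halogen substitution on this aryl ring in general, with compounds 1 and 4 as the cases against such a pattern. The data offer no measured basis for explaining either the separation of compound 2 or the lack of separation among the other three.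

The compounds shown do not settle whether the lower number of compound 2 depends on the bromine itself, since a single chlorine in the same place would be needed to separate the halogen from the substitution pattern. Also open, going by these compounds, is how this aryl ring responds to non-halogen groups, such as a methoxy group, an amine or a carboxylic acid.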